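Ester Side Chains and Lipophilicity in a Nucleoside Series

This account rests on a few compounds, and the source may have more. Where it says the series, first, only, none or still open, it means among the compounds named here.

Compound 1 `CCCCCCCC(=O)OC[C@H]1O[C@@H](n2cnc3c(N)ncnc32)[C@@H](O)[C@@H]1O` in a physicochemical assay for lipophilicity, using the shake flask method, in phosphate buffer, with a stated time of 1 h (a higher number here means a more lipophilic compound, a lower number a more polar compound), gives >= 2; this is a limit of the assay and not a number.
Compound 2 `CCCCC(=O)OC[C@H]1O[C@@H](n2cnc3c(N)ncnc32)[C@@H](O)[C@@H]1O` in this assay gives 1.33.
Compound 3 `Nc1ncnc2c1ncn2[C@@H]1O[C@H](COC(=O)c2ccccc2)[C@@H](O)[C@@H]1O` in this assay gives 1.34.

Within the data shown here, compound 3 and compound 2 sit within the usual scatter of each other, and the only other value is the limit of compound 1, (the limit of >= 2 in this assay, at which 1 of the 3 values shown sits). Compound 4 `CCCC(=O)OC[C@H]1O[C@@H](n2cnc3c(N)ncnc32)[C@@H](O)[C@@H]1O` differs from compound 3 by propyl in place of phenyl on a carbonyl carbon. Among the measured compounds shown here, two measured steps bear on this change. The first, a number 0.01 log units higher from compound 2 to compound 3 (within the scatter), shows that the phenyl ester and the butyl ester read alike. The second, a number at least 0.67 log units lower from compound 1 to compound 2 (beyond the scatter), shows that hydrogen in place of propyl on the saturated chain lowered the value clearly. Propyl in place of butyl is a smaller change of that same kind, so a modest decrease is expected, estimated as a number 0.49 log units lower from compound 3 to compound 4 (beyond the scatter). Compound 4 is therefore expected to give 0.85, within a range from 0.5 to 1.2.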

Compound 4, partition coefficient: 0.9
Compound 4: middle estimate off by 0.05 log units, on the low side, and the stated range covers the measured number.
By their numbers in this assay, from the lowest: compound 4; then compounds 2 and 3 (each within the scatter of the next). At a limit, above all of these: compound 1.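

In this assay, removing one methyl from the saturated chain on the carbonyl carbon is enough to shift the reading: a number 0.43 log units lower from compound 2 to compound 4 (beyond the scatter). Phenyl and butyl read alike at this position, but phenyl and propyl do not: a number 0.44 log units lower from compound 3 to compound 4 (beyond the scatter). The heptyl ester reads only as a limit of the assay, and the full span of the chain series stands as a minimum: a number at least 1.10 log units lower from compound 1 to compound 4 (beyond the scatter).

The compounds shown leave open how a branched chain, or a chain carrying an amine or a carboxylic acid, would read. On these data alone, a phenyl ring bearing a fluorine also remains open.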